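The source may hold more compounds than are shown below. What is called first, only, known or untested is meant among the compounds shown, and "the series" means these compounds.

Of the compounds shown here, two of the shared core have so far been measured in a functional assay on the whole organism (strain albino) with Mus musculus as the target, in the maximal electroshock model, with a stated time of 0.5 h; on this read-out lower numbers stand for an effect already at smaller amounts and higher numbers for an effect only at larger amounts of compound. Compound 1 `Cc1ccccc1Nc1nnc(Nc2nc(-c3ccccc3)cs2)s1` gives 300 mg/kg, while compound 2 `COc1ccc(Nc2nnc(Nc3nc(-c4ccccc4)cs3)s2)cc1` gives 100 mg/kg. For the measured compounds named here, the single measured step, a 3.0-fold lower number from compound 1 to compound 2 (0.48 log units; beyond the scatter), connects them. Going by the values given here, compound 2 thus stands at the lowest of the two numbers known, with compound 1 as its nearest neighbour. The next compound, compound 3 `c1ccc(Nc2nnc(Nc3nc(-c4ccccc4)cs3)s2)cc1`, differs from compound 2 by hydrogen in place of methoxy on an aromatic carbon. Among the compounds with values here, no measured step concerns the methoxy group itself; the only step at hand, a 3.0-fold lower number from compound 1 to compound 2 (0.48 log units; beyond the scatter), exchanged one substituted phenyl for another and was modest. That step does not bear directly on removing the methoxy, so compound 3 is expected to stay close to compound 2 in this assay. For compound 3 the expected step is a 1.5-fold higher number from compound 2 to compound 3 (0.18 log units; within the scatter). The estimate for compound 3 is 150 mg/kg, within a range from 50 mg/kg to 450 mg/kg.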

Compound 3, minimum effective dose: 300 mg/kg
Beside the measured number, compound 3's estimate is 2.0-fold (0.30 log units) below it, and the stated range covers the measured number.
By their numbers in this assay, from the lowest: compound 2; then compounds 1 and 3 (each within the scatter of the next).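

In this assay, going from 4-methoxyphenyl to phenyl gives a 3.0-fold higher number from compound 2 to compound 3 (0.48 log units; beyond the scatter), so the lower number of this small set depends on the methoxy on this aromatic carbon, para to a large group, which the earlier exchange of one substituted phenyl for another could not isolate. The methyl on the other ring carbon shows no such dependence: hydrogen in its place gives no change at the digits printed from compound 1 to compound 3 (within the scatter). Nothing available explains why the two groups differ in this way.

The compounds shown leave open whether a hydroxyl, an amine or a longer ethoxy chain on the same aromatic carbon would keep the number seen for compound 2. They also leave open whether a methyl on that carbon would behave as the methoxy does.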